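The source may hold more compounds than are shown below. What is called first, only, known or untested is meant among the compounds shown, and "the series" means these compounds.

Measured compounds in an ADME assay on HEK293 cells for agonist activity at metabotropic glutamate receptor 5 (Rattus norvegicus), read by fluorescence and calcium flux; a higher number here means a larger maximal response, a lower number a smaller maximal response:

compound 1 `Cc1ccccc1C#Cc1ccc(C(=O)N[C@H](C)C(C)(C)O)nc1` — compound 1 gives 24.1%
compound 2 `C[C@@H](NC(=O)c1ncc(C#Cc2cccc(F)c2)cn1)C(C)(C)O` — compound 2 gives 19.2%
compound 3 `CCCNC(=O)c1ccc(C#Cc2cccc(F)c2)cn1` — compound 3 gives 8.3%

Compound 3 stands lowest of the three numbers in this assay. Its nearest neighbour is compound 2, whose number lies above it by more than the scatter, and compound 1 lies further above still, also beyond the scatter. Both compound 1 and compound 2 carry a hydroxyl-bearing amide substituent; compound 3 carries a plain propyl amide.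

Compound 4 `CC(C)(O)CNC(=O)c1ccc(C#Cc2cccc(F)c2)cn1` is not yet measured. Against compound 3 the change is 1-hydroxy-1-methylethyl in place of ethyl on a saturated chain carbon bound to an amide-type nitrogen, that is 1-hydroxy-1-methylethyl in place of ethyl, one bond out from the amide-type nitrogen; the amide, the shared core and the 3-fluorophenyl-alkyne are unchanged.

Among the compounds with values here, no measured pair isolates this change. The expectation rests on the fact that the two hydroxyl-bearing compounds sit higher: compound 1 gives 24.1% and compound 2 gives 19.2% in this assay. On that basis a step upward, somewhat beyond the scatter, is expected for compound 4: a number 8.7 percentage points higher from compound 3 to compound 4 (within the scatter).

The estimate for compound 4 in this assay is 17%, with a range from 8% to 28%.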

Compound 4, largest response reached (reported as efficacy), in percent of the reference or control that the assay uses: 20%
Compound 4: middle estimate off by 3 percentage points, on the low side; low and high end bracket the measured number.
By their numbers in this assay, from the lowest: compound 3; then compounds 2, 4 and 1 (each within the scatter of the next).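

In this assay, within the data shown here, 1-hydroxy-1-methylethyl in place of ethyl on a saturated chain carbon bound to an amide-type nitrogen gives a number 11.7 percentage points higher from compound 3 to compound 4 (beyond the scatter) and is the only comparison that differs in one place, with the amide, the shared core and the 3-fluorophenyl-alkyne unchanged. Compounds 1, 2 and 3 differ in more than one place, so they could only suggest a link between a hydroxyl-bearing amide substituent and a larger maximal response, whereas this pair shows that the number moves with this change alone, and that this end of the amide chain is a position where a substituent change can register beyond the scatter. No measurement at hand speaks to why the number moves.

The change adds the hydroxyl and extra carbon together, so it remains open which of the two accounts for the step; a 2-methylpropyl chain and a 2-hydroxyethyl chain on the same amide would separate them. Also open, from the compounds shown here alone, is how a primary amine or a carboxylic acid would read at this position, and whether the step carries over to the other cores.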